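Chloro for Fluoro on the Aryl Ring of Compound 3

The source may hold more compounds than are shown below. What is called first, only, known or untested is meant among the compounds shown, and "the series" means these compounds.

Compound 3 `Fc1ccc(-c2nc3ccc(N4CCCCC4)nc3s2)cc1` gives 26.5 nM in an assay on isolated protein for inhibition of Amine oxidase [flavin-containing] B (Homo sapiens), read by fluorescence, with a stated time of 1 h (on this read-out lower numbers stand for stronger inhibition and higher numbers for weaker inhibition), the lowest of the three numbers at hand. Compound 2 `c1ccc(-c2nc3ccc(N4CCCCC4)nc3s2)cc1` gives 356 nM, and compound 1 `Fc1ccccc1-c1nc2ccc(N3CCCCC3)nc2o1` gives 665 nM. For the measured compounds named here, the only single-point step recorded is a 13-fold lower number from compound 2 to compound 3 (1.13 log units; beyond the scatter), brought about by a fluoro in place of hydrogen on an aromatic carbon. Compound 4 `Clc1ccccc1-c1nc2ccc(N3CCCCC3)nc2s1` differs from compound 3 by 2-chlorophenyl in place of 4-fluorophenyl on an aromatic carbon. Going by the values given here, no measured step covers this change directly; compound 1 carries a 2-chlorophenyl-like ortho pattern only in the loose sense of a 2-fluorophenyl on a different core and shows a higher number than compound 3, but the cores differ. Compound 4 is expected to give back much of that gain, because the fluoro behind a 13-fold lower number from compound 2 to compound 3 (1.13 log units; beyond the scatter) leaves, amounting to an estimated 11-fold higher number from compound 3 to compound 4 (1.05 log units; beyond the scatter). The estimate for compound 4 is 300 nM, within 60 nM to 1500 nM.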

Compound 4, half-maximal inhibitory concentration: 171 nM
Compound 4: middle estimate off by 1.8-fold (0.24 log units), on the high side, within the range that was stated.
By their numbers in this assay, from the lowest: compound 3; then compound 4; then compounds 2 and 1 (each within the scatter of the next).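

In this assay, the exchange of groups gives a 6.5-fold higher number from compound 3 to compound 4 (0.81 log units; beyond the scatter), yet the 2-chlorophenyl group still stands apart from the plain phenyl, with a 2.1-fold lower number from compound 2 to compound 4 (0.32 log units; beyond the scatter). Among these three compounds on the shared core, both halogen-bearing phenyl groups therefore give lower numbers than plain phenyl, with the larger step being a 13-fold lower number from compound 2 to compound 3 (1.13 log units; beyond the scatter). Nothing available explains the difference between the two groups.

Here the halogen and its ring position change together, so their contributions cannot be separated. The compounds shown leave open how 4-chlorophenyl or 2-fluorophenyl on the shared core would compare.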